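A few compounds are considered here, and "the series" means these few. Any claim that something is new, unique, unknown or untested is made for them only; others in the source may bear on it.

Compound 3, `C=C1C(=O)[C@]23C[C@@]1(O)CC[C@H]2c1ccc(OS(=O)(=O)c2ccc(C)cc2)c(C)c1[C@@H]3Cn1cc(-c2ccc(F)cc2)nn1`, was tested in a functional assay on MCF7 cells (Homo sapiens) for cytotoxicity, read by MTT assay, with a stated time of 4 days (on this read-out lower numbers stand for stronger inhibition and higher numbers for weaker inhibition), where compound 3 gives 330 nM. This is the lowest of the two numbers recorded so far. Compound 1, `C=C1C(=O)[C@]23C[C@@]1(O)CC[C@H]2c1ccc(O)c(C)c1[C@@H]3Cn1cc(-c2ccc(C)cc2)nn1`, lies nearest: in this assay compound 1 gives 370 nM, a number that sits within the scatter of repeated measurements of the value for compound 3, so no order between compound 1 and compound 3 can be read from these two values. Compound 2, `Cc1ccc(S(=O)(=O)Oc2ccc3c(c2C)[C@H](Cn2cc(-c4ccc(F)cc4)nn2)[C@@]24CC(=O)[C@@](C)(CC[C@@H]32)C4)cc1`, is a different case. In this assay, among the compounds with values here, compound 2 shows only a limit, > 20000 nM, rather than a number, the limit of > 20000 nM in this assay, at which 1 of the 3 values shown sits, being the one such value among the three.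

The step under examination leads from compound 3 to compound 4, `C=C1C(=O)[C@]23C[C@@]1(O)CC[C@H]2c1ccc(OS(=O)(=O)c2ccc(C)cc2)c(C)c1[C@@H]3Cn1cc(-c2ccccn2)nn1`. The change is pyridin-2-yl in place of 4-fluorophenyl on an aromatic carbon. Within the data shown here, no step between two measured compounds in this set isolates a single change, so the size of the effect on this assay cannot be checked against any recorded pair. The author therefore expects the step from compound 3 to compound 4 to be small, with a modest weakening more likely than a gain, and the expected step reads a 1.7-fold higher number from compound 3 to compound 4 (0.22 log units; within the scatter). On that basis compound 4 is estimated to give 550 nM in this assay, with a range from 150 nM to 2500 nM.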

Compound 4, half-maximal inhibitory concentration: 320 nM
For compound 4 the middle estimate is 1.7-fold (0.24 log units) above the measured one; the range from low to high includes it.
By their numbers in this assay, from the lowest: compounds 4, 3 and 1 (each within the scatter of the next). At a limit, above all of these: compound 2.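

In this assay, within the data shown here, pyridin-2-yl in place of 4-fluorophenyl gives a 1.0-fold lower number from compound 3 to compound 4 (0.01 log units; within the scatter), the first step in this set that isolates a single change. On an aromatic carbon of a five-membered aromatic ring with 3 nitrogen, a six-membered aromatic ring of carbon only bearing fluorine and a six-membered aromatic ring with 1 hetero atom, which also carries the hydrogen-bond acceptor counted for pyridin-2-yl, thus give values that cannot be told apart in this assay. None of the measurements shown here bears on why these two values cannot be told apart.

The compounds shown leave open whether this position would give a similar number with a group other than an aromatic ring, such as an amine, a carboxylic acid or a longer chain. Compound 2 remains at a limit of the assay, > 20000 nM, and no single-change step links it to any other compound shown, so what separates it from the others also stays open.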